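The source may hold more compounds than are shown below. What is called first, only, known or untested is meant among the compounds shown, and "the series" means these compounds.

Measured in an assay on CHO cells for displacement of a labelled ligand from 5-hydroxytryptamine receptor 7 (Homo sapiens); on this read-out lower numbers stand for stronger inhibition and higher numbers for weaker inhibition:

Compound 1 `CCC1(CCCCN2CCN(c3cccc(Cl)c3)CC2)C(=O)Nc2ccccc21` — 0.41 nM
Compound 2 `CCC1(CCCCN2CCN(c3ccc(C)c(Cl)c3)CC2)C(=O)Nc2ccccc21` — 0.66 nM

Compound 1 stands lowest of the two numbers in this assay. Its nearest neighbour is compound 2, reached by the step of a 1.6-fold higher number from compound 1 to compound 2 (0.21 log units; within the scatter), a methyl in place of hydrogen on an aromatic carbon; this step lies within the scatter, so the two compounds cannot be ordered against each other.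

Compound 3 `CCC1(CCCCN2CCN(c3cccc(Cl)c3)CC2)C(=O)Nc2cc(F)ccc21` is not yet measured. It differs from compound 1 by fluoro in place of hydrogen on an aromatic carbon. Within the data shown here, no measured step touches the fused two-ring part of the shared core: the single step in hand, a 1.6-fold higher number from compound 1 to compound 2 (0.21 log units; within the scatter), changes the other aromatic ring, the one outside the fused system, and stays within the scatter. The data therefore give no basis for expecting a shift beyond the scatter in either direction from a small substituent on the fused ring, and the expectation is that the step of a 1.5-fold higher number from compound 1 to compound 3 (0.17 log units; within the scatter) is small.

Compound 3 is estimated at 0.6 nM in this assay, with a plausible range from 0.2 nM to 1.8 nM.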

Compound 3, inhibition constant: 0.67 nM
Compound 3: middle estimate off by 1.1-fold (0.05 log units), on the low side, and the stated range covers the measured number.
By their numbers in this assay, from the lowest: compounds 1, 2 and 3 (each within the scatter of the next).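

In this assay, the fused two-ring part of the shared core now has a measured change: fluoro in place of hydrogen on an aromatic carbon, meta to a fused ring and para to a fused ring, gives a 1.6-fold higher number from compound 1 to compound 3 (0.21 log units; within the scatter). This position therefore accepts this single fluorine atom with no shift that can be told from the scatter, and the series now has a readable step on the fused system as well as on the outer aromatic ring, where the methyl change gives a 1.6-fold higher number from compound 1 to compound 2 (0.21 log units; within the scatter). No measurement available here bears on why the fluoro step stays this small.

On these data alone, the result covers only one small substituent at one position, so it remains open whether a methoxy group, an amine or a carboxylic acid at the same carbon would also stay within the scatter. As far as these compounds go, the other aromatic carbons of the fused system also remain open, and a single fluoro step gives no basis for extending this reading to them.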